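The source may hold more compounds than are shown below. What is called first, only, known or untested is meant among the compounds shown, and "the series" means these compounds.

Compound 1 `CCOC(=O)c1c(-c2cccc(-c3ccccc3)c2)[nH]c2cc(OC)c(Cl)cc2c1=O`: > 21500 nM (a limit)
Compound 2 `CCOC(=O)c1c(-c2cccc(Oc3ccccc3)c2)[nH]c2cc(OC)c(Cl)cc2c1=O`: > 21500 nM (a limit)

Both compounds were tested in an ADME assay on HepG2 cells (Homo sapiens) for cytotoxicity, read by luminescence, with a stated time of 72 h (on this read-out higher numbers stand for an effect only at larger amounts of compound and lower numbers for an effect already at smaller amounts), and neither gave a number. Within the data shown here, compound 2 stands at > 21500 nM and this is a limit of the assay, as is the only other value available. Compound 3 `CCOC(=O)c1c(-c2cccc(Cl)c2)[nH]c2cc(OC)c(Cl)cc2c1=O` carries chloro in place of phenoxy on an aromatic carbon, meta to a large group chloro in place of phenoxy on an aromatic carbon and is otherwise unchanged. Among the measured compounds shown here, the one measured step that touches the phenoxy group is a step that the two limits leave unreadable from compound 1 to compound 2 and so it offers no size to carry over. For the measured compounds named here, no step beyond the scatter is expected in this assay because the limit of > 21500 nM in this assay, at which 2 of the 2 values shown sit, and no measured compound gives a lower reading. Going by these compounds, the estimated change is a number no higher from compound 2 to compound 3 (the limit leaves the size open) and its direction stays open. Compound 3 is expected at 21500 nM with an estimated range from 10000 nM to 40000 nM and may well turn out to be only a limit.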

Compound 3, half-maximal effective concentration: > 21500 nM
Compound 3: no number, only a limit; the forecaster's own chance of this, stated with the estimate: 80%; the middle value lies on the limit itself.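

Compound 3 gives > 21500 nM, which is a limit of the assay, so its steps from compound 1 and from compound 2 cannot be read. The compounds shown leave open how compound 1, compound 2 and compound 3 compare in this assay, and at what concentration any of them would give a number.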